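The source may hold more compounds than are shown below. What is called first, only, known or untested is meant among the compounds shown, and "the series" means these compounds.

Measured compounds:
compound 1, `CC(C)c1onc(-c2ccc(S(C)(=O)=O)cc2Cl)c1COc1ccc(/C=C/c2cccc(C(=O)O)c2)c(Cl)c1`, > 10000 nM
compound 2, `Cc1cc(OCc2c(-c3c(Cl)ccc(=O)n3C)noc2C(C)C)ccc1-c1ccc2c(C(=O)O)cn(C)c2c1`, 4000 nM

In a functional assay for agonist activity at Bile acid receptor (Homo sapiens), read by a luciferase reporter (a lower number here means that less compound is needed, a higher number that more compound is needed for the effect), compound 1 is reported only as a limit, > 10000 nM, not as a number; (the limit of > 10000 nM in this assay, at which 1 of the 2 values shown sits). Among the measured compounds shown here, compound 2, by contrast, gives a number in this assay, 4000 nM, and so it is the only compound here with a measured value rather than a limit. For the measured compounds named here, the two measured compounds differ in many places at once, and no single step between them can be separated out. Nothing can be said about which of their differences carries the change from a limit to a number.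

Compound 3, `Cc1cc(OCc2c(-c3ccn(C)c(=O)c3Cl)noc2C(C)C)ccc1-c1ccc2c(C(=O)O)cn(C)c2c1`, is not yet measured. It differs from compound 2 in one place: a group of 9 heavy atoms (6 carbon, 1 nitrogen, 1 oxygen, 1 chlorine; one six-membered aromatic ring with 1 hetero atom) in place of a group of 9 heavy atoms (6 carbon, 1 nitrogen, 1 oxygen, 1 chlorine; one six-membered aromatic ring with 1 hetero atom), on an aromatic carbon. The two compounds contain the same atoms, joined differently, so the change is one of arrangement rather than of composition. Going by the values given here, no measured pair shows the effect of such a rearrangement, so no direction can be read off from the data. In this assay the step from compound 2 to compound 3 is therefore expected to be small, a 1.1-fold lower number from compound 2 to compound 3 (0.06 log units; within the scatter), not beyond the usual scatter in either direction. Compound 3 is expected to give about 3500 nM in this assay, within a range from 1000 nM to 12000 nM.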

Compound 3, half-maximal effective concentration: 7000 nM
Compound 3: middle estimate off by 2.0-fold (0.30 log units), on the low side, and the stated range covers the measured number.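

In this assay, among the compounds shown here, moving the atoms within the group on the aromatic carbon of the five-membered aromatic ring with 1 nitrogen and 1 oxygen gives a 1.8-fold higher number from compound 2 to compound 3 (0.24 log units; within the scatter); this is the first step that can be read in one place. At this position, then, the two arrangements of one six-membered aromatic ring with 1 hetero atom, which have the same atoms and the same counts of double bonds and hydrogen-bond acceptors, cannot be told apart in this assay, and both compound 2 and compound 3 give numbers rather than limits. Compound 1 remains the only compound reported as a limit, and its many differences from the others still cannot be separated: the limit of > 10000 nM in this assay, at which 1 of the 3 values shown sits.

Because this single step compares only two arrangements of the same atoms, it leaves open how the number would respond to a different group at this position, such as a plain phenyl ring, a pyridine ring without the chlorine, or a ring carrying a methoxy group. It also leaves open whether the isopropyl group on the same ring could give way to a cyclopropyl group without a step beyond the scatter.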